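Adding an amino group to compound 2

A few compounds are considered here, and "the series" means these few. Any claim that something is new, unique, unknown or untested is made for them only; others in the source may bear on it.

Measured so far in an ADME assay on BaF3 cells (Mus musculus) for antiproliferative activity, read by CellTiter-Glo and CCK-8 assay, with a stated time of 72 h; on this read-out lower numbers stand for stronger inhibition of growth and higher numbers for weaker inhibition of growth:
Compound 1 `Cc1ccc(Nc2ncc3c(n2)N(C)C(=O)N(c2cc(NC(=O)c4cccc(C(F)(F)F)c4)ccc2C)C3)cc1C` gives 3760 nM
Compound 2 `Cc1ccc(Nc2ncc3c(n2)N(C)C(=O)N(c2cc(NC(=O)c4cccc(C(F)(F)F)c4)ccc2C)C3)cc1` gives 8000 nM
Compound 3 `Cc1ccc(NC(=O)c2cccc(C(F)(F)F)c2)cc1N1Cc2cnc(OC3CCN(C(=O)OC(C)(C)C)CC3)nc2N(C)C1=O` gives > 10000 nM as a limit of the assay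

Compound 2 holds the higher of the two true numbers, and compound 1 is its nearest neighbour, the gap being a 2.1-fold higher number from compound 1 to compound 2 (0.33 log units; beyond the scatter) in this assay on this read-out. The entry for compound 3 is a limit.

The step in question leads to compound 4 `Cc1ccc(Nc2ncc3c(n2)N(C)C(=O)N(c2cc(NC(=O)c4cccc(C(F)(F)F)c4)ccc2C)C3)cc1N`, which has not yet been measured. The change is amino in place of hydrogen on an aromatic carbon.

Among the measured compounds shown here, only one measured step touches this same carbon, namely a 2.1-fold higher number from compound 1 to compound 2 (0.33 log units; beyond the scatter), a modest change with hydrogen in place of methyl. In that single pair, the compound with a group on this carbon has the lower number. A modest step towards a lower number is therefore expected in this assay for compound 4, of about the same size. For the measured compounds named here, no measured compound carries the amino group, however, so this guide is loose, and a step within the scatter remains possible.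

The estimated change is a 2.0-fold lower number from compound 2 to compound 4 (0.30 log units; within the scatter) in this expectation. For compound 4 the estimate is 4000 nM with an expected range from 1500 nM to 10000 nM in this assay.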

Compound 4, concentration for 50% growth inhibition: 440 nM
Beside the measured number, compound 4's estimate is 9.1-fold (0.96 log units) above it; the measured number lies below the stated range.
By their numbers in this assay, from the lowest: compound 4; then compound 1; then compound 2. At a limit, above all of these: compound 3.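

In this assay, amino in place of hydrogen on this aromatic carbon brings an 18-fold lower number from compound 2 to compound 4 (1.26 log units; beyond the scatter), a large step at a position where the earlier compounds had shown only a modest one. Amino in place of methyl on the same carbon still brings an 8.5-fold lower number from compound 1 to compound 4 (0.93 log units; beyond the scatter), whereas the only earlier pair, which compares methyl with hydrogen, shows a 2.1-fold higher number from compound 1 to compound 2 (0.33 log units; beyond the scatter). The result therefore shows that the outcome at this carbon, ortho to a methyl group, depends strongly on which group sits there and not merely on whether a group is present.

The compounds shown leave open whether a hydroxyl, a methylamino or an acetamide group on this carbon would keep the lower number, and whether amino on another carbon of the same ring would do the same. Nothing given here bears on why the amino group brings so large a step.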